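Oleyl amide to urea: one step in the series

The source may report more compounds than this note shows. Statements on the series, on what has been measured and on what is new or still open speak of the compounds shown alone.

Among the measured compounds shown here, compound 1 `CCCCCCCC/C=C\CCCCCCCCNC(=O)c1c(C)cccc1C` is the only member of this set with a measured number. In an assay on microsomes from intestinal mucosa for inhibition of acyl-CoA:cholesterol acyltransferase (Oryctolagus cuniculus) (a lower number here means a stronger inhibitor, a higher number a weaker inhibitor), compound 1 gives 9800 nM. The companion compound 2 `CCCCCCCCCCCCCCCCCCSc1c(C)cccc1C` carries a thioether in place of the amide. In this assay compound 2 gives > 10000 nM, which is a limit of the assay and not a number. Compound 1 therefore stands alone as a point on the scale, and the limit of > 10000 nM in this assay, at which 1 of the 2 values shown sits, marks where the other value sits. For the measured compounds named here, no step between two measured compounds is available for calibration.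

Compound 3 `CCCCCCCC/C=C\CCCCCCCCNC(=O)Nc1c(C)cc(C)cc1C` has not yet been measured in this assay. It differs from compound 1 by (2,4,6-trimethylphenyl)amino in place of 2,6-dimethylphenyl on a carbonyl carbon; the change turns the amide into a urea and brings one hydrogen-bond donor with it, as counted in that difference. The step from compound 1 to compound 3 is expected to move toward stronger inhibition, beyond the usual scatter, estimated as an 8.2-fold lower number from compound 1 to compound 3 (0.91 log units; beyond the scatter). Compound 3 is therefore expected to give 1200 nM in this assay, with a likely range from 200 nM to 6000 nM.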

Compound 3, half-maximal inhibitory concentration: 2900 nM
The estimate for compound 3 lay 2.4-fold (0.38 log units) below the measured number, and the stated range covers the measured number.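

In this assay, among the compounds shown here, (2,4,6-trimethylphenyl)amino in place of 2,6-dimethylphenyl on the carbonyl carbon gives a 3.4-fold lower number from compound 1 to compound 3 (0.53 log units; beyond the scatter), the first step in this set that can be read as a number, and it shows that this position responds to change. The step is modest and bundles two changes: the amide becomes a urea with one hydrogen-bond donor entering, and the aromatic group changes from 2,6-dimethylphenyl to 2,4,6-trimethylphenyl, so the size of the step cannot be divided between them. Nothing available gives a measured property that bears on this step.

A urea carrying 2,6-dimethylphenyl, or an amide carrying 2,4,6-trimethylphenyl, would separate the contribution of the urea nitrogen from that of the added methyl group. Going by these compounds, the oleyl chain is the same on both sides of the step, so it also remains open whether the step holds with a shorter saturated chain, or with a carboxylic acid at the end of the chain.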